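A few compounds are considered here, and "the series" means these few. Any claim that something is new, unique, unknown or untested is made for them only; others in the source may bear on it.

Compound 1 `COc1ncc(-c2ccc3c(c2)N(c2ccc(C)cc2)C(=O)CO3)cc1NS(=O)(=O)c1ccc(F)cc1` carries a 4-methylphenyl group on its amide nitrogen, and in a functional assay on HCT-116 cells (Homo sapiens) for antiproliferative activity, read by MTT assay, with a stated time of 72 h (a lower number here means a stronger inhibitor, a higher number a weaker inhibitor), compound 1 gives 22700 nM. Compound 2 `Cc1ccc(N2C(=O)COc3ccc(-c4cnc(Cl)c(NS(=O)(=O)c5ccc(F)cc5)c4)cc32)cc1` differs from compound 1 at another place, and in this assay compound 2 gives 34300 nM. Within the data shown here, of the two numbers so far, compound 1 stands lowest, with compound 2 its nearest neighbour; the one measured step, a 1.5-fold higher number from compound 1 to compound 2 (0.18 log units; within the scatter), lies within the scatter, so the two compounds cannot be ranked. Compound 3 `COc1ncc(-c2ccc3c(c2)N(c2ccc(Cl)cc2)C(=O)CO3)cc1NS(=O)(=O)c1ccc(F)cc1` has not yet been measured. It differs from compound 1 by chloro in place of methyl on an aromatic carbon. Among the measured compounds shown here, no measured step follows this change directly: the only step available, a 1.5-fold higher number from compound 1 to compound 2 (0.18 log units; within the scatter), exchanges chloro for methoxy elsewhere in the molecule and, lying within the scatter, gives no sign of how an exchange on the 4-methylphenyl part of compound 1 might move the number. The step expected in this assay is therefore none beyond the scatter, in either direction, which reads as a 1.1-fold higher number from compound 1 to compound 3 (0.04 log units; within the scatter). Compound 3 is estimated at 25000 nM, with a range from 9000 nM to 70000 nM.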

Compound 3, half-maximal inhibitory concentration: 19200 nM
Compound 3: the middle estimate sits 1.3-fold (0.11 log units) above what was measured; low and high end bracket the measured number.
By their numbers in this assay, from the lowest: compounds 3, 1 and 2 (each within the scatter of the next).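

In this assay the exchange of 4-methylphenyl for 4-chlorophenyl gives a 1.2-fold lower number from compound 1 to compound 3 (0.07 log units; within the scatter), so compound 1 and compound 3 cannot be ranked. Among these compounds, this is the first reading at this position, on an aromatic carbon para to a large group, since the earlier step concerned an exchange elsewhere in the molecule; it shows that, of these two groups, neither sets a number apart from the other, and that chloro is accepted here with the number staying within the scatter of that for methyl. No measurement of any property of these groups accompanies the result, so the data offer no account of it.

Whether this position responds at all remains open, since methyl and chloro are the only groups shown there, and an amine, a carboxylic acid or a longer chain such as propyl might or might not move the number beyond the scatter. Also open, from the compounds shown here alone, is whether the exchange of chloro for methoxy elsewhere in the molecule would read the same with the 4-chlorophenyl group in place.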